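This account rests on a few compounds, and the source may have more. Where it says the series, first, only, none or still open, it means among the compounds named here.

Working notes on the series. The shared core is that of compound 1 `Nc1cc(N)c2nc(-c3ccccc3)c(NCc3ccc(Cl)c(Cl)c3)nc2c1`, which in a functional assay on KM12 cells (Homo sapiens) for inhibition, read by sulforhodamine B assay, with a stated time of 48 h (a higher number here means a weaker inhibitor of growth, a lower number a stronger inhibitor of growth), gives 21400 nM. Compound 2 `Nc1cc(N)c2nc(-c3ccccc3)c(Oc3ccc(F)cc3)nc2c1` carries a 4-fluorophenoxy group on the same aromatic carbon and in this assay gives 40700 nM; the values of compound 1 and compound 2 lie within the usual scatter of each other. Compound 3 `Nc1cc(N)c2nc(-c3ccccc3)c(Sc3ccc(Cl)c(Cl)c3)nc2c1` bears a (3,4-dichlorophenyl)sulfanyl group at that carbon. In this assay compound 3 is reported only as a limit, < 100000 nM. Compound 3 therefore stands without a number, and the step that the limit leaves unreadable from compound 2 to compound 3 is unreadable in size because of the limit of < 100000 nM in this assay, at which 1 of the 3 values shown sits.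

Compound 4 `Nc1cc(N)c2nc(-c3ccccc3)c(NCc3ccc(F)cc3)nc2c1` is the next member to be measured. It differs from compound 3 as follows: (4-fluorobenzyl)amino in place of (3,4-dichlorophenyl)sulfanyl on an aromatic carbon. Among the compounds with values here, no measured step bears directly on this change. Within the data shown here, the only step recorded, a step that the limit leaves unreadable from compound 2 to compound 3, gives no size. What can be drawn on is that compound 4 shares the benzylamino attachment with compound 1, which gives 21400 nM, and that the 4-fluoro aryl of compound 2 gives 40700 nM. On this basis compound 4 is expected to fall in the same region as compound 1. The expected step is a step that the limit leaves unreadable from compound 3 to compound 4, which cannot be set against a limit. Compound 4 is estimated at 30000 nM, with a range of 10000 nM to 90000 nM.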

Compound 4, concentration for total growth inhibition: 7410 nM
Compound 4: the middle estimate sits 4.0-fold (0.61 log units) above what was measured; the whole stated range lies above it.
By their numbers in this assay, from the lowest: compound 4; then compounds 1 and 2 (each within the scatter of the next).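

The new value gives the first differences beyond the scatter in this series, and both involve the (4-fluorobenzyl)amino group on the aromatic carbon next to the ring nitrogen. With the 4-fluoro aryl kept, (4-fluorobenzyl)amino in place of 4-fluorophenoxy gives a 5.5-fold lower number from compound 2 to compound 4 (0.74 log units; beyond the scatter) in this assay, so this position responds to a change in the link to the aryl in at least this pair, and 4-fluorophenyl in place of 3,4-dichlorophenyl with the benzylamino attachment kept gives a 2.9-fold lower number from compound 1 to compound 4 (0.46 log units; beyond the scatter), so the aryl substitution also registers, which the values of compound 1 and compound 2 alone, lying within the scatter of each other and differing in more than one feature, could not show. The step involving compound 3 cannot be read because compound 3 is reported only as a limit: the limit of < 100000 nM in this assay, at which 1 of the 4 values shown sits.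

The compounds shown leave open whether the gain from 4-fluorophenyl would carry over to the phenoxy or sulfanyl links, since no pair isolates that change. Also open, going by these compounds, is how an unsubstituted benzylamino group, a longer chain such as phenethylamino, or a cyclic amine such as morpholine would read at this carbon.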